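Removing the hydroxy from a morpholine amide: toxicity outlook

The source may hold more compounds than are shown below. What is called first, only, known or untested is meant among the compounds shown, and "the series" means these compounds.

Measured so far:
Compound 1 `CCCCCC[C@@H](O)C/C=C\CCCCCCCC(=O)N[C@@H](C)c1ccccc1` – 9.7 ug/mL
Compound 2 `CCCCCC[C@@H](O)C/C=C\CCCCCCCC(=O)N1CCOCC1` – 41.3 ug/mL
Compound 3 `CCCCCCCCCCCCCCCCCC(=O)N1CCCC1` – 6.3 ug/mL

In an ADME assay on HaCaT cells (Homo sapiens) for cytotoxicity, read by sulforhodamine B assay, with a stated time of 48 h (on this read-out higher numbers stand for lower toxicity in this test and lower numbers for higher toxicity in this test), compound 2 gives 41.3 ug/mL, the highest number of the three and therefore the least toxic in this test. Its closest neighbour is compound 1, which gives 9.7 ug/mL, and the widest gap is to compound 3 with 6.3 ug/mL; both gaps lie beyond the scatter. Among the measured compounds shown here, the one step that has been measured directly, a 4.3-fold higher number from compound 1 to compound 2 (0.63 log units; beyond the scatter), changes the group on the carbonyl carbon, not the chain.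

Compound 4 `CCCCCCCC/C=C\CCCCCCCC(=O)N1CCOCC1` is the next member. It differs from compound 2 only in the chain: hydrogen in place of hydroxy on a saturated chain carbon bound to two saturated chain carbons. For the measured compounds named here, no measured step covers this exact change. Compound 3 also lacks the hydroxy and gives a lower number than compound 2, but it differs from compound 2 in more than one place, so it offers only a loose hint. Given that, a modest move toward a lower number in this assay is expected, with real uncertainty. Compound 4 is estimated at 25 ug/mL, within a range of 10 ug/mL to 60 ug/mL, which would mean an expected step of a 1.7-fold lower number from compound 2 to compound 4 (0.22 log units; within the scatter).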

Compound 4, concentration lethal to 50% of the cells: 5.3 ug/mL
Compound 4: the middle estimate sits 4.7-fold (0.67 log units) above what was measured; measured number outside the range, below it.
By their numbers in this assay, from the lowest: compounds 4, 3 and 1 (each within the scatter of the next); then compound 2.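

Replacing the hydroxy with hydrogen on a saturated chain carbon bound to two saturated chain carbons gives, in this assay, a 7.8-fold lower number from compound 2 to compound 4 (0.89 log units; beyond the scatter), so this single change in the chain means higher toxicity in this test. Among the compounds shown here, until now, the only direct step was at the other end of the molecule, on the carbonyl carbon: a 4.3-fold higher number from compound 1 to compound 2 (0.63 log units; beyond the scatter). Read together, the two steps show that the high number of compound 2 goes with having both the hydroxy and the morpholin-4-yl group, since compound 1 keeps the hydroxy without the morpholin-4-yl group and compound 4 keeps the morpholin-4-yl group without the hydroxy, and no measurement at hand explains why removing the hydroxy has this effect.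

The compounds shown leave open whether another group on that same saturated chain carbon, such as a methoxy, an amine or a ketone carbonyl, would keep the number of compound 2 or lose it as compound 4 does. They also leave open whether removing the hydroxy from compound 1, with its (1-phenylethyl)amino group, would give a step of similar size.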